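Swapping Methoxy for Chloro on the Aryl Group of Compound 3

The compounds below may be only part of what the source reports. "The series", "measured", "known", "first", "only" and "open" are said of these compounds alone.

Three measured compounds share one core and differ only in the aryl group carried on the aromatic nitrogen. Compound 1 `COc1cc2c(Oc3ccc(NC(=O)c4nn(-c5ccccc5C)c(=O)cc4C)cc3F)ccnc2cc1OCCCN1CCN(C)CC1` gives 2830 nM in a functional assay on A549 cells (Homo sapiens) for inhibition, read by MTT assay, with a stated time of 72 h; on this read-out higher numbers stand for weaker inhibition and lower numbers for stronger inhibition. Compound 2 `COc1cc2c(Oc3ccc(NC(=O)c4nn(-c5ccccc5OC(F)(F)F)c(=O)cc4C)cc3F)ccnc2cc1OCCCN1CCN(C)CC1` gives 130 nM in this assay, and compound 3 `COc1ccc(-n2nc(C(=O)Nc3ccc(Oc4ccnc5cc(OCCCN6CCN(C)CC6)c(OC)cc45)c(F)c3)c(C)cc2=O)cc1` gives 2200 nM in this assay. Compound 3 thus stands second highest of the three numbers: its value lies within the scatter of compound 1, as a 1.3-fold lower number from compound 1 to compound 3 (0.11 log units; within the scatter) shows, whereas a 17-fold higher number from compound 2 to compound 3 (1.23 log units; beyond the scatter) is a large step beyond the scatter.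

Compound 4 `COc1cc2c(Oc3ccc(NC(=O)c4nn(-c5ccc(Cl)cc5)c(=O)cc4C)cc3F)ccnc2cc1OCCCN1CCN(C)CC1` differs from compound 3 by chloro in place of methoxy on an aromatic carbon. Among the measured compounds shown here, none of the measured steps touches this change directly: a 22-fold lower number from compound 1 to compound 2 (1.34 log units; beyond the scatter) replaces methyl with trifluoromethoxy on a different aryl group, and the other two steps exchange the whole aryl group at once. For the measured compounds named here, the data therefore offer no close precedent, and only a modest step is expected, a 1.8-fold lower number from compound 3 to compound 4 (0.26 log units; within the scatter). Compound 4 is expected to give about 1200 nM in this assay, within a range from 300 nM to 5000 nM.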

Compound 4, half-maximal inhibitory concentration: 270 nM
Compound 4: middle estimate off by 4.4-fold (0.65 log units), on the high side; measured number outside the range, below it.
By their numbers in this assay, from the lowest: compound 2; then compound 4; then compounds 3 and 1 (each within the scatter of the next).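

The earlier compounds shown here showed the 4-methoxyphenyl group only within the scatter of compound 1, so they gave no sign that a substituent at this aromatic carbon, para to a large group, could matter in this assay. Chloro in place of methoxy gives an 8.1-fold lower number from compound 3 to compound 4 (0.91 log units; beyond the scatter) and thus moves the number beyond the scatter, and the 4-chlorophenyl group separates clearly from the 2-methylphenyl group, with a 10-fold lower number from compound 1 to compound 4 (1.02 log units; beyond the scatter). Compound 2 still holds the lowest number, with a 2.1-fold higher number from compound 2 to compound 4 (0.32 log units; beyond the scatter) and so the 2-(trifluoromethoxy)phenyl group stays ahead of 4-chlorophenyl.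

Nothing available explains why chloro and methoxy differ here. Going by these compounds, whether fluoro, trifluoromethoxy or an amine on this same carbon would fall nearer to chloro or to methoxy remains open.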